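From (pyridin-2-yl)methoxy to 2-cyclopropylethyl

The source may report more compounds than this note shows. Statements on the series, on what has been measured and on what is new or still open speak of the compounds shown alone.

Measured so far in an ADME assay (liver) for pharmacokinetics, with Liver microsome (Rattus norvegicus) as the target, read by LC-MS, using microsomes, tested at 2 uM; a lower number here means slower removal, a higher number faster removal of the compound:
compound 1 `O=C(N[C@@H]1CCCC[C@H]1O)c1cnc(OCc2ncccn2)c(-c2ccc(Cl)cc2)c1`: 0.012 mL/min/kg
compound 2 `O=C(N[C@@H]1CCCC[C@H]1O)c1cnc(OCc2cccnc2)c(-c2ccc(Cl)cc2)c1`: 0.374 mL/min/kg
compound 3 `O=C(N[C@@H]1CCCC[C@H]1O)c1cnc(OCc2ccccn2)c(-c2ccc(Cl)cc2)c1`: 0.044 mL/min/kg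

Compound 3 is second highest of the three numbers. The gaps around it are a 3.7-fold higher number from compound 1 to compound 3 (0.56 log units; beyond the scatter) and an 8.5-fold lower number from compound 2 to compound 3 (0.93 log units; beyond the scatter).

Compound 4 `O=C(N[C@@H]1CCCC[C@H]1O)c1cnc(CCC2CC2)c(-c2ccc(Cl)cc2)c1` differs from it at one place, on an aromatic carbon next to the ring nitrogen: 2-cyclopropylethyl in place of (pyridin-2-yl)methoxy on an aromatic carbon.

The closest evidence comes from exchanges of the aromatic ring in the same side group, the widest being a 31-fold higher number from compound 1 to compound 2 (1.49 log units; beyond the scatter). These steps show that the number responds to changes in this group. None of them replaces the whole (pyridin-2-yl)methoxy group, so they bear on the new change only loosely.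

A modest upward step in this assay is expected, with low confidence, as compound 2 at 0.374 mL/min/kg shows how far up the series reaches. The expected step is a 3.4-fold higher number from compound 3 to compound 4 (0.53 log units; beyond the scatter). For compound 4 the estimated value is 0.15 mL/min/kg, with an expected range of 0.03 mL/min/kg to 0.7 mL/min/kg.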

Compound 4, clearance: 1.5 mL/min/kg
The estimate for compound 4 lay 10-fold (1.00 log units) below the measured number; the whole stated range lies below it.
By their numbers in this assay, from the lowest: compound 1; then compound 3; then compound 2; then compound 4.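

In this assay, putting 2-cyclopropylethyl in place of (pyridin-2-yl)methoxy on the aromatic carbon next to the ring nitrogen gives a 34-fold higher number from compound 3 to compound 4 (1.53 log units; beyond the scatter). The same exchange starting from the other two side groups gives a 4.0-fold higher number from compound 2 to compound 4 (0.60 log units; beyond the scatter) and a 130-fold higher number from compound 1 to compound 4 (2.10 log units; beyond the scatter), so the step stays beyond the scatter whichever aromatic ring leaves. Among these four compounds, all three side groups carrying an oxygen and an aromatic ring sit lower than 2-cyclopropylethyl, with no compound against this, and exchanges of the ring alone did not show where the number goes once the whole group is replaced.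

Which part of the change carries the step stays open: a cyclopropylmethoxy group or a 2-(pyridin-2-yl)ethyl chain would separate the oxygen from the aromatic ring. No measurement at hand gives a reason for the rise.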